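A few compounds are considered here, and "the series" means these few. Any claim that something is new, unique, unknown or untested is made for them only; others in the source may bear on it.

Measured so far:
compound 1, `CC(C)c1c(C(=O)N2CCC[C@H](c3ccccc3)C2)nn(-c2ccc(F)cc2)c1CC[C@@H](O)C[C@@H](O)CC(=O)O`, 2.1 nM
compound 2, `CC(C)c1c(C(=O)N2CCCC2c2ccccc2)nn(-c2ccc(F)cc2)c1OC[C@@H](O)C[C@@H](O)CC(=O)O`, 14 nM

In an assay on microsomes from liver for inhibition of 3-hydroxy-3-methylglutaryl-coenzyme A reductase (Rattus norvegicus) (on this read-out lower numbers stand for stronger inhibition and higher numbers for weaker inhibition), compound 1 gives 2.1 nM. Compound 2 gives 14 nM in this assay, the higher of the two numbers, and the gap to compound 1 lies beyond the scatter. Among the measured compounds shown here, no single-change pair among the measured compounds is available, so no measured step can be quoted.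

Compound 3, `CC(C)c1c(C(=O)N2CCC[C@H](c3ccccc3)C2)nn(-c2ccc(F)cc2)c1OC[C@@H](O)C[C@@H](O)CC(=O)O`, is not yet measured. It differs from compound 2 in one place: 3-phenylpiperidin-1-yl in place of 2-phenylpyrrolidin-1-yl on a carbonyl carbon. The entering 3-phenylpiperidin-1-yl group is the same amide substituent carried by compound 1, which gives 2.1 nM in this assay, whereas compound 2 with the 2-phenylpyrrolidin-1-yl group gives 14 nM. On these two numbers alone the change is expected to move compound 3 toward a lower number, by a moderate step that may just pass the scatter, rather than to leave it unchanged. The expected step is a 2.3-fold lower number from compound 2 to compound 3 (0.37 log units; beyond the scatter). For compound 3 the estimate in this assay is 6 nM, with a range from 2 nM to 18 nM.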

Compound 3, half-maximal inhibitory concentration: 4.8 nM
Beside the measured number, compound 3's estimate is 1.3-fold (0.10 log units) above it, within the range that was stated.
By their numbers in this assay, from the lowest: compound 1; then compound 3; then compound 2.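

With the (5-carboxy-2,4-dihydroxypentyl)oxy chain held constant, the group on the carbonyl carbon now has a single-change reading in this assay: 3-phenylpiperidin-1-yl in place of 2-phenylpyrrolidin-1-yl gives a 2.9-fold lower number from compound 2 to compound 3 (0.46 log units; beyond the scatter) and so the amide substituent alone moves the number beyond the scatter. With 3-phenylpiperidin-1-yl held constant, the chain on the aromatic carbon can also be read alone: (5-carboxy-2,4-dihydroxypentyl)oxy in place of 6-carboxy-3,5-dihydroxyhexyl gives a 2.3-fold higher number from compound 1 to compound 3 (0.36 log units; beyond the scatter) and this modest step shows that the two places can each shift the number in this assay. No measurement at hand accounts for either step.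

The amide change alters ring size, the attachment point of the phenyl and the defined stereocentre together, so 3-phenylpyrrolidin-1-yl, 2-phenylpiperidin-1-yl or the opposite enantiomer of 3-phenylpiperidin-1-yl would be needed to separate these features, while unsubstituted piperidin-1-yl would test the phenyl itself. Whether the amide step carries over to the 6-carboxy-3,5-dihydroxyhexyl chain also remains open, as the 2-phenylpyrrolidin-1-yl amide on that chain is not among the compounds shown.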